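Swapping the sulfur substituent in compound 1 for a pyrimidinyl ethyl group

The compounds below may be only part of what the source reports. "The series", "measured", "known", "first", "only" and "open" are said of these compounds alone.

Measured so far:
compound 1 `Cn1ncc2c(=O)n(-c3ccccc3)c(SC(C)(C)c3ccccc3)nc21`: 2200 nM
compound 2 `CC(Sc1nc2nn(C3COC3)cc2c(=O)n1-c1ccccc1)c1ccccn1`: 21 nM
compound 3 `CC(Sc1nc2nn(CC3COC3)cc2c(=O)n1-c1ccccc1)c1ccccc1`: 80 nM

In an assay on isolated protein for inhibition of retinal dehydrogenase 2 (Homo sapiens) (a lower number here means a stronger inhibitor, a higher number a weaker inhibitor), compound 1 gives the highest of the three numbers, and its gaps to compound 3 and to compound 2 both lie beyond the usual scatter, so compound 1 is the weakest inhibitor here.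

Compound 4 `CC(Sc1nc2c(cnn2C)c(=O)n1-c1ccccc1)c1cncnc1` keeps the core of compound 1 and changes only the group on the sulfur: 1-(pyrimidin-5-yl)ethyl in place of 1-methyl-1-phenylethyl on a sulfur

For the measured compounds named here, no measured pair shows this exact step, so its size is not known. Because compound 2 gives 21 nM and compound 3 gives 80 nM, both far lower than compound 1, a move toward lower numbers is expected for compound 4, estimated as a step of an 11-fold lower number from compound 1 to compound 4 (1.04 log units; beyond the scatter) to 200 nM (range 40 nM to 1000 nM).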

Compound 4, half-maximal inhibitory concentration: 380 nM
Estimate against measurement, compound 4: 1.9-fold (0.28 log units) below, within the range that was stated.
By their numbers in this assay, from the lowest: compound 2; then compound 3; then compound 4; then compound 1.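

With 1-(pyrimidin-5-yl)ethyl in place of 1-methyl-1-phenylethyl on the sulfur, this assay shows a 5.8-fold lower number from compound 1 to compound 4 (0.76 log units; beyond the scatter) while the rest of the molecule stays the same. This is the only single-place change shown, so this drop can be tied directly to the group on the sulfur. No measurement bears on why the number falls.

The step swaps the ring and removes a methyl together, so it leaves open which of the two matters. Going by these compounds, how 1-(pyrazin-2-yl)ethyl or a longer chain such as 1-(pyrimidin-5-yl)propyl would behave on the sulfur also stays open.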